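The compounds below may be only part of what the source reports. "The series", "measured", "known", "first", "only" and "open" are said of these compounds alone.

Going by the values given here, in an ADME assay on RAW264.7 cells (Mus musculus) for cytotoxicity, read by MTT assay, with a stated time of 48 h (a higher number here means that more compound is tolerated, a lower number that less compound is tolerated), compound 2 (`C#CCOc1ccc(-c2noc(N(CC#C)C3CCCCC3)n2)cc1`) gives 101 ug/mL, the highest of the three numbers so far. Compound 1 (`CC(=O)OC[C@H]1O[C@H](OC[C@@H](Cn2cc(CN(c3nc(-c4ccc(Br)cc4)no3)C3CCCCC3)nn2)OC(C)=O)C=C[C@@H]1OC(C)=O`) gives 39.1 ug/mL and compound 3 (`C#CCOc1ccc(-c2noc(NC3CCCCC3)n2)cc1`) gives 38.3 ug/mL, each lower than compound 2 by more than the scatter.

Next in the series is compound 4 (`C#CCN(c1nc(-c2ccc(Br)cc2)no1)C1CCCCC1`), which keeps the propargyl on the nitrogen of compound 2 but has bromo in place of propargyloxy on an aromatic carbon, para to a large group: bromo in place of propargyloxy on an aromatic carbon.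

Among the compounds with values here, no measured pair isolates this change. Within the data shown here, the only measured step, a 2.6-fold lower number from compound 2 to compound 3 (0.42 log units; beyond the scatter), has hydrogen in place of propargyl on a nitrogen. It is modest and beyond the scatter, but it does not touch the aromatic carbon in question, so it serves only as a rough guide to size in this small set. Bromo does occur in compound 1 at 39.1 ug/mL, but that compound also carries a much larger group on the nitrogen, so its number is weak evidence for direction.

Among the measured compounds shown here, the estimate for the change is a 1.7-fold lower number from compound 2 to compound 4 (0.23 log units; within the scatter), expected toward a lower number and no larger than the one measured step. For compound 4 the expected value is 60 ug/mL, with an estimated range from 25 ug/mL to 130 ug/mL.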

Compound 4, half-maximal cytotoxic concentration: 15.7 ug/mL
Beside the measured number, compound 4's estimate is 3.8-fold (0.58 log units) above it; the whole stated range lies above it.
By their numbers in this assay, from the lowest: compound 4; then compounds 3 and 1 (each within the scatter of the next); then compound 2.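

In this assay, going by these compounds alone, the aromatic carbon para to a large group turns out to matter: a 6.4-fold lower number from compound 2 to compound 4 (0.81 log units; beyond the scatter) is the first measured step at this position, and it exceeds the only earlier step from the same compound, a 2.6-fold lower number from compound 2 to compound 3 (0.42 log units; beyond the scatter) at the nitrogen. The result therefore shows that, with the propargyl on the nitrogen held constant, propargyloxy and bromo are not interchangeable at this carbon: a group of 4 heavy atoms with a triple bond and a hydrogen-bond acceptor gives way to a single bromine atom, and the number falls beyond the scatter. No measurement available here explains this step.

With only these two groups compared at this carbon, the compounds shown do not separate the loss of propargyloxy from the arrival of bromo; a hydrogen, a methoxy, a hydroxy or a chloro at the same place would help to tell these apart. Also open, on these data alone, is whether the step from propargyloxy to bromo keeps its size when hydrogen replaces the propargyl on the nitrogen, as it does in compound 3.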